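Cytotoxicity notes: indolyl for dimethoxypyrimidinyl on the biaryl

The source may report more compounds than this note shows. Statements on the series, on what has been measured and on what is new or still open speak of the compounds shown alone.

Measured so far:
- compound 1 `CC(C)N(Cc1cccc(OCCCCCC(=O)O)c1)C(=O)c1ccccc1`: > 26000 nM
- compound 2 `CC(C)COc1cccc(-c2ccc(C(=O)N(Cc3cccc(OCCCCCC(=O)O)c3)C(C)C)cc2)c1`: > 26000 nM
- compound 3 `CCOC(=O)CCCCCOc1cccc(CN(C(=O)c2ccc(-c3cnc(OC)nc3OC)cc2)C(C)C)c1`: > 26000 nM

For the measured compounds named here, every value so far in an ADME assay on Raji cells (Homo sapiens) for cytotoxicity, read by CellTiter-Glo and resazurin assay, with a stated time of 72 h (on this read-out lower numbers stand for an effect already at smaller amounts and higher numbers for an effect only at larger amounts of compound), is a limit of the assay and not a number. Compound 1 sits at its limit of > 26000 nM in this assay. Compound 2 sits at the same limit in this assay. Compound 3, the starting point here, likewise sits at a limit of > 26000 nM in this assay, so nothing places it relative to the other two: the limit of > 26000 nM in this assay, at which 3 of the 3 values shown sit.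

Going by the values given here, the one step between measured compounds, a step that the two limits leave unreadable from compound 1 to compound 2, has a size the two limits leave unreadable. It is therefore no guide to the change now considered, compound 4 `CCOC(=O)CCCCCOc1cccc(CN(C(=O)c2ccc(-c3ccc4cc[nH]c4c3)cc2)C(C)C)c1`, which differs from compound 3 by 1H-indol-6-yl in place of 2,4-dimethoxypyrimidin-5-yl on an aromatic carbon.

With no readable step and all three values at the limit, compound 4 is expected to stay at the limit as well, estimated at 30000 nM in this assay. The range 10000 nM to 80000 nM is expected to hold it. The step that the limit leaves unreadable from compound 3 to compound 4 is thus expected to be none beyond the scatter.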

Compound 4, half-maximal effective concentration: > 26000 nM
Compound 4 ended at the assay's limit; the forecaster's own chance of this, stated with the estimate: 70%; the middle value lies beyond the limit too.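

In this assay, compound 3 and compound 4 both stand at a limit of the assay and not at a number, so no step between them can be read: the limit of > 26000 nM in this assay, at which 4 of the 4 values shown sit.

The compounds shown leave open whether any change to this series gives a readable value in this assay.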